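A few compounds are considered here, and "the series" means these few. Any claim that something is new, unique, unknown or untested is made for them only; others in the source may bear on it.

In an assay (Canis lupus familiaris) for binding affinity to platelet-activating factor receptor (Homo sapiens), read by radioligand binding (on this read-out lower numbers stand for stronger inhibition and higher numbers for weaker inhibition), compound 1 `C=CCc1cc(C(=O)N[C@H](C)CCCc2cccnc2)ccc1-c1ccc(OC)c(OC)c1` gives 80 nM. Compound 2 `O=C(NCCCCc1cccnc1)c1ccc(-c2cccc(F)c2)c(F)c1` gives 2100 nM in this assay, a higher number than compound 1, and the gap between them lies beyond the scatter. For the measured compounds named here, compound 1 therefore stands at the lower of the two numbers measured so far.

Compound 3 `COc1ccc(-c2ccc(C(=O)N[C@H](C)CCCc3cccnc3)cc2[N+](=O)[O-])cc1OC` has not yet been measured in this assay. It differs from compound 1 in one place: nitro in place of allyl on an aromatic carbon. Going by the values given here, no pair of measured compounds shows this change by itself, so its effect is not known from the data at hand. The expected step from compound 1 to compound 3 is a 1.9-fold higher number from compound 1 to compound 3 (0.27 log units; within the scatter), a small shift toward a higher number that may not exceed the scatter. On that basis compound 3 is estimated at 150 nM in this assay, with a range from 50 nM to 500 nM.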

Compound 3, half-maximal inhibitory concentration: 200 nM
The estimate for compound 3 lay 1.3-fold (0.12 log units) below the measured number; measured number inside the range.
By their numbers in this assay, from the lowest: compound 1; then compound 3; then compound 2.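

In this assay the swap of allyl for nitro gives a 2.5-fold higher number from compound 1 to compound 3 (0.40 log units; beyond the scatter) at the aromatic carbon ortho to a 3,4-dimethoxyphenyl group. For the compounds shown here, this is the first reading at this position, and it shows that the position responds to the change, though only modestly: the two groups have the same count of heavy atoms and each has one double bond outside aromatic rings, while nitro brings two hydrogen-bond acceptors and allyl none. Nothing in the data at hand bears on why the number rises.

A single pair cannot separate what is lost with allyl from what is gained with nitro. As far as these compounds go, how hydrogen, an amine, a carboxylic acid or a longer chain would read on this carbon remains open.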